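Anilide-to-dichlorophenyl switch on the trimethoxyphenyl pyrazole chalcone

A few compounds are considered here, and "the series" means these few. Any claim that something is new, unique, unknown or untested is made for them only; others in the source may bear on it.

Of the compounds shown here, two carry numbers so far. Compound 1 `COc1ccc(-c2cc(/C=C/C(=O)c3ccc(N)cc3)[nH]n2)cc1` was run in a functional assay on OVCAR-8 cells (Homo sapiens) for cytotoxicity, read by sulforhodamine B assay, with a stated time of 48 h, tested at 100 uM (on this read-out lower numbers stand for a stronger effect and higher numbers for a weaker effect at the one concentration tested), and gives -41%. Compound 2 `COc1cc(-c2cc(/C=C/C(=O)c3ccc(N)cc3)[nH]n2)cc(OC)c1OC` gives in this assay the value -91%, which is the lowest of the two numbers; the nearest, compound 1, sits a good deal higher, beyond the scatter. Within the data shown here, no single-site step between measured compounds is available, so nothing measured says how the ketone-side aryl group moves the read-out.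

Compound 3 `COc1cc(-c2cc(/C=C/C(=O)c3ccc(Cl)c(Cl)c3)[nH]n2)cc(OC)c1OC` differs from compound 2 in one place: 3,4-dichlorophenyl in place of 4-aminophenyl on a carbonyl carbon. The 4-aminophenyl leaves and 3,4-dichlorophenyl enters on the carbonyl carbon.

Among the measured compounds shown here, with no precedent for this exchange, a moderate step toward weaker effect, rather than none, is the working expectation; compound 3 is estimated at -70% in this assay, within -100% to -20%. That estimate corresponds to an expected change of a number 21 percentage points higher from compound 2 to compound 3 (beyond the scatter).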

Compound 3, a percentage reported as activity, at one concentration (the size of the read-out at that concentration, not a potency): -36%
Beside the measured number, compound 3's estimate is 34 percentage points below it; low and high end bracket the measured number.
By their numbers in this assay, from the lowest: compound 2; then compounds 1 and 3 (each within the scatter of the next).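

In this assay, among these compounds, the group on the carbonyl carbon now has a measured effect for the first time: 3,4-dichlorophenyl in place of 4-aminophenyl gives a number 55 percentage points higher from compound 2 to compound 3 (beyond the scatter), a large move toward a weaker effect. This position is therefore not neutral in this series, and the 4-aminophenyl of compound 2 outperforms the 3,4-dichlorophenyl of compound 3 on this one pair. The exchange also removes the hydrogen-bond donor and acceptor counted on 4-aminophenyl, but nothing available links that difference to the step.

A single exchange cannot separate the loss of the amine from the arrival of the two chlorines; an unsubstituted phenyl, an acetamide or a carboxylic acid on the same ring would help divide the two. From the compounds shown here alone, whether the step carries over to the core of compound 1 also remains open.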